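The compounds below may be only part of what the source reports. "The series", "measured", "known", "first", "only" and "open" are said of these compounds alone.

Of the compounds shown here, two have so far been measured in an assay on V79 cells for inhibition of cytochrome P450 11B1, mitochondrial (Homo sapiens), read by HTRF, with a stated time of 1 h; on this read-out lower numbers stand for stronger inhibition and higher numbers for weaker inhibition. Compound 1 `Fc1cc2nc(-c3cccnc3)n(C3CC3)c2cc1F` gives 370 nM in this assay. Compound 2 `CC(C)(C)n1c(-c2cccnc2)nc2ccc(F)cc21` gives > 10000 nM in this assay, and that figure is a limit of the measurement rather than a number: it sits at the limit of > 10000 nM in this assay, at which 1 of the 2 values shown sits. Compound 3 `CCn1c(-c2cccnc2)nc2ccc(F)cc21` differs from compound 2 by ethyl in place of tert-butyl on an aromatic nitrogen. Among the compounds with values here, no measured pair tracks this change on its own. Stronger inhibition is nonetheless expected, by about an at least 6.6-fold lower number from compound 2 to compound 3 (0.82 log units; beyond the scatter), a step beyond the usual scatter. Compound 3 is estimated at 1500 nM, within 300 nM to 8000 nM.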

Compound 3, half-maximal inhibitory concentration: 2100 nM
The estimate for compound 3 lay 1.4-fold (0.15 log units) below the measured number; the range from low to high includes it.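

In this assay, the group on this aromatic nitrogen clearly matters: ethyl in place of tert-butyl gives an at least 4.7-fold lower number from compound 2 to compound 3 (0.67 log units; beyond the scatter). The entry for compound 2 is a limit and not a number: the limit of > 10000 nM in this assay, at which 1 of the 3 values shown sits. On these data alone, the true size of the step therefore stays unknown, but compound 3 shows that this nitrogen can carry ethyl and still give a measurable value. As far as these compounds go, whether methyl or a longer unbranched chain such as n-propyl would give a lower or higher number stays open. A single step also cannot separate chain length from branching.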